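The compounds below may be only part of what the source reports. "The series", "measured", "known", "first", "only" and "open" are said of these compounds alone.

Compound 2 `CC1(C)CC12NC(=O)N(NC(=O)c1ccc(F)cc1)C2=O` gives 300 mg/kg in a functional assay on the whole organism (Hindlimb) for inhibition, with Mus musculus as the target, with a stated time of 4 h (a higher number here means that more compound is needed for the effect, a lower number that less compound is needed), the highest of the two numbers measured. Its nearest neighbour is compound 1 `CC(C)(C)c1ccc(C(=O)NN2C(=O)NC3(CC3(C)C)C2=O)cc1`, which gives 100 mg/kg in this assay; the gap between them is a 3.0-fold higher number from compound 1 to compound 2 (0.48 log units; beyond the scatter), where fluoro replaced tert-butyl on an aromatic carbon. Compound 3 `CC1(C)CC12NC(=O)N(NC(=O)c1ccc(C(F)(F)F)cc1)C2=O` carries trifluoromethyl in place of fluoro on an aromatic carbon. That single measured step bears on this change: swapping a larger group for fluoro raised the number, so putting a larger group back is expected to lower it modestly. Compound 3 is therefore expected to give 100 mg/kg, within 30 mg/kg to 300 mg/kg, a step estimated as a 3.0-fold lower number from compound 2 to compound 3 (0.48 log units; beyond the scatter).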

Compound 3, minimum effective dose: 30 mg/kg
Beside the measured number, compound 3's estimate is 3.3-fold (0.52 log units) above it; the range from low to high includes it.
By their numbers in this assay, from the lowest: compound 3; then compound 1; then compound 2.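

At this place on the aromatic ring, trifluoromethyl needs less compound than either earlier group in this assay: there is a 10-fold lower number from compound 2 to compound 3 (1.00 log units; beyond the scatter), and a 3.3-fold lower number from compound 1 to compound 3 (0.52 log units; beyond the scatter). Tert-butyl therefore no longer gives the lowest number, and the three groups now rank trifluoromethyl, tert-butyl, fluoro, from lowest to highest. No measurement shown here explains this order. As far as these compounds go, it remains open whether a chlorine atom, a nitrile or a methoxy group at this place would lower the number further. The compounds also leave open whether this order would hold on a different core.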